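Second Methoxy Group Added to Compound 1

A few compounds are considered here, and "the series" means these few. Any claim that something is new, unique, unknown or untested is made for them only; others in the source may bear on it.

Compound 1 `COc1cccc(C(=O)NC2CCN(Cc3ccc4ccccc4c3)CC2)c1` was examined in an assay on isolated protein for binding affinity to melanin-concentrating hormone receptor 1 (Homo sapiens) (on this read-out lower numbers stand for stronger inhibition and higher numbers for weaker inhibition), where compound 1 gives 29 nM. Compound 2 `CCOc1cc(OCC)cc(C(=O)NC2CCN(Cc3ccc4ccccc4c3)CC2)c1` gives 56 nM in this assay; the two values lie within the usual scatter of each other, so compound 1 carries the lowest of the two numbers without standing apart from compound 2. Compound 3 `COc1ccc(C(=O)NC2CCN(Cc3ccc4ccccc4c3)CC2)cc1OC` differs from compound 1 by methoxy in place of hydrogen on an aromatic carbon. Among the measured compounds shown here, no measured pair traces this change, so nothing beyond the two values supports an expectation. The step of a 1.4-fold higher number from compound 1 to compound 3 (0.14 log units; within the scatter) is expected to stay within the scatter. Compound 3 is accordingly estimated at 40 nM, with a range from 12 nM to 130 nM.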

Compound 3, inhibition constant: 1000 nM
Compound 3: the middle estimate sits 25-fold (1.40 log units) below what was measured; the measured number lies above the stated range.
By their numbers in this assay, from the lowest: compounds 1 and 2 (each within the scatter of the next); then compound 3.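

In this assay, methoxy in place of hydrogen on the aromatic carbon para to the large group, ortho to the methoxy group of compound 1, gives a 34-fold higher number from compound 1 to compound 3 (1.54 log units; beyond the scatter). Among the compounds shown here, this single change, 3-methoxyphenyl to 3,4-dimethoxyphenyl, shows that the value at this position is highly sensitive to what it carries, which the earlier compounds could not reveal. Nothing available explains the loss. The compounds shown leave open whether a fluorine atom or a hydroxyl group at this carbon would keep the value of compound 1, and whether methoxy here would cost as much without the neighbouring methoxy group.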